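This account rests on a few compounds, and the source may have more. Where it says the series, first, only, none or still open, it means among the compounds named here.

Measured so far in a functional assay on LNCaP cells (Homo sapiens) for antiproliferative activity, read by WST assay, with a stated time of 3 days; on this read-out higher numbers stand for weaker inhibition and lower numbers for stronger inhibition:
- compound 1 `CCCCOc1c(-c2cc(OC)c(OC)c(OC)c2)oc2ccccc2c1=O` gives 8900 nM
- compound 2 `CCCCCCOc1c(-c2cc(OC)c(OC)c(OC)c2)oc2ccccc2c1=O` gives 19600 nM
- compound 3 `CCCN(CCC)CCCCOc1c(-c2cc(OC)c(OC)c(OC)c2)oc2ccccc2c1=O` gives 16800 nM

Compound 3 stands within the scatter of both other compounds, as a 1.9-fold higher number from compound 1 to compound 3 (0.28 log units; within the scatter) and a 1.2-fold lower number from compound 2 to compound 3 (0.07 log units; within the scatter) show. Only a 2.2-fold higher number from compound 1 to compound 2 (0.34 log units; beyond the scatter) goes beyond the scatter, and that step is modest.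

The next compound is compound 4 `CCCCN(CCCC)CCCCCOc1c(-c2cc(OC)c(OC)c(OC)c2)oc2ccccc2c1=O`, and the change from compound 3 is this: (dibutylamino)methyl in place of dipropylamino on a saturated chain carbon, four bonds along the chain from an oxygen on an aromatic ring. All three measured steps fall at this same place on the chain, so all bear on the change. None of them, however, pairs one amine with another or separates a longer chain from larger groups on the nitrogen. Going by the values given here, the closest precedent, a 1.2-fold lower number from compound 2 to compound 3 (0.07 log units; within the scatter), stays within the scatter, and the largest, a 2.2-fold higher number from compound 1 to compound 2 (0.34 log units; beyond the scatter), is modest. In this assay, as far as these compounds go, no step beyond the scatter is therefore expected, and the direction remains open. The expected change is a 1.3-fold lower number from compound 3 to compound 4 (0.11 log units; within the scatter). For compound 4 the estimated value is 13000 nM (range 4500 nM to 30000 nM).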

Compound 4, half-maximal inhibitory concentration: 7800 nM
For compound 4 the middle estimate is 1.7-fold (0.22 log units) above the measured one, and the stated range covers the measured number.
By their numbers in this assay, from the lowest: compounds 4, 1, 3 and 2 (each within the scatter of the next, the first and the last beyond it).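

In this assay, going by these compounds alone, (dibutylamino)methyl in place of dipropylamino on a saturated chain carbon, four bonds along the chain from an oxygen on an aromatic ring, gives the first step between two amine-bearing chains, a 2.2-fold lower number from compound 3 to compound 4 (0.33 log units; beyond the scatter), so this position distinguishes one such chain from another, though only modestly. Dibutylamino in place of methyl gives a 2.5-fold lower number from compound 2 to compound 4 (0.40 log units; beyond the scatter), also modest, while (dibutylamino)methyl in place of hydrogen gives a 1.1-fold lower number from compound 1 to compound 4 (0.06 log units; within the scatter), leaving compound 4 level with compound 1 despite the much larger chain. Nothing available explains these steps.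

As far as these compounds go, compound 4 changes the chain length and the groups on the nitrogen together, so the share of each stays open. Also open, from the compounds shown here alone, is how dipropylamino on the longer chain, dibutylamino on the shorter chain, or a piperidine at this place would read.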